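This account rests on a few compounds, and the source may have more. Where it says the series, first, only, none or still open, it means among the compounds named here.

Compound 3 `O=C(O)CCc1ccncc1-c1ccc2ccccc2c1` carries a hydroxy on its carbonyl carbon, and compound 1 `CNC(=O)CCc1ccncc1-c1ccc2ccccc2c1` differs from it only by methylamino in place of hydroxy on a carbonyl carbon. In a functional assay on MDA-MB-231 cells (Homo sapiens) for inhibition, read by sulforhodamine B assay, with a stated time of 72 h (on this read-out higher numbers stand for weaker inhibition of growth and lower numbers for stronger inhibition of growth), compound 3 gives only a limit of the assay, > 10000 nM. Compound 1 gives 8980 nM in this assay. The measured step is therefore an at least 1.1-fold lower number from compound 3 to compound 1 (0.04 log units; that floor lies within the scatter), and that it is given only as a floor follows from the limit of > 10000 nM in this assay, at which 2 of the 3 values shown sit. Compound 2 `Cn1ccc2cc(-c3cnccc3/C=C/C(=O)O)ccc21` has a different core; how the two cores differ is not broken down here. In this assay compound 2 also gives only a limit, > 10000 nM. Compound 4 `CNC(=O)/C=C/c1ccncc1-c1ccc2c(ccn2C)c1` differs from compound 2 by methylamino in place of hydroxy on a carbonyl carbon. The places are not word for word the same, since the carbonyl carbon's other neighbour is a double-bonded chain carbon rather than a saturated chain carbon, so this is the same kind of change, not the same change. Because the measured step was an at least 1.1-fold lower number from compound 3 to compound 1 (0.04 log units; that floor lies within the scatter), little movement is expected, and compound 4 is estimated at 10000 nM. For compound 4 this means an expected step of a number no higher from compound 2 to compound 4 (the limit leaves the size open).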

Compound 4, concentration for 50% growth inhibition: 8550 nM
For compound 4 the middle estimate is 1.2-fold (0.07 log units) above the measured one; low and high end bracket the measured number.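

On the core of compound 2, methylamino in place of hydroxy on a carbonyl carbon gives an at least 1.1-fold lower number from compound 2 to compound 4 (0.06 log units; that floor lies within the scatter). The change carries over only in a narrow sense, in that both methylamino compounds give a number where both hydroxy compounds give only a limit: the same change on two cores in this assay, an at least 1.1-fold lower number (0.04 log units; that floor lies within the scatter) from compound 3 to compound 1 and an at least 1.1-fold lower number (0.06 log units; that floor lies within the scatter) from compound 2 to compound 4; the limit leaves it open whether they differ. It remains unshown whether the change lowers the number by a real amount on either core, or by the same amount on both, and both steps rest on one limit: the limit of > 10000 nM in this assay, at which 2 of the 4 values shown sit.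

The compounds shown leave open what a dimethylamino or an ethylamino group would do on this carbonyl carbon. Also open, on these data alone, is how the saturated chain and the double-bonded chain compare on a single core.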